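A few compounds are considered here, and "the series" means these few. Any claim that something is new, unique, unknown or untested is made for them only; others in the source may bear on it.

Measured compounds in an ADME assay on MCF7 cells (Homo sapiens) for cytotoxicity, read by MTT assay, with a stated time of 11 days; on this read-out lower numbers stand for stronger inhibition of growth and higher numbers for weaker inhibition of growth:
compound 1, `CCCCCc1cc2c(=O)n(CCC)cnc2s1`: 33.8 ug/mL
compound 2, `CCCCCc1cc2c(=O)n(CC3CC3)cnc2s1`: > 100 ug/mL

Compound 1 `CCCCCc1cc2c(=O)n(CCC)cnc2s1` gives 33.8 ug/mL in this assay. Compound 2 `CCCCCc1cc2c(=O)n(CC3CC3)cnc2s1` reaches only a limit of this assay, > 100 ug/mL, so that no number is known for it; it sits at the limit of > 100 ug/mL in this assay, at which 1 of the 2 values shown sits. Going by the values given here, the step of an at least 2.9-fold higher number from compound 1 to compound 2 (0.47 log units; beyond the scatter) therefore is a change at the end of the shared core carrying the cyclopropyl, and it is the only step in hand.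

Compound 3 `CCCCCCc1cc2c(=O)n(CC3CC3)cnc2s1` differs from compound 2 by methyl in place of hydrogen on a saturated chain carbon, five bonds along the chain from an aromatic carbon. Among the compounds with values here, no measured step touches this chain; the one step known concerns the cyclopropyl end. The data thus give no ground to expect movement beyond the scatter in this assay from compound 2 to compound 3, and compound 2 itself stands only at a limit. Compound 3 is expected to stay near that limit, with an estimated step that the limit leaves unreadable from compound 2 to compound 3. The estimate for compound 3 is 150 ug/mL, in the range 60 ug/mL to 400 ug/mL.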

Compound 3, concentration for 50% growth inhibition: 24.8 ug/mL
Estimate against measurement, compound 3: 6.0-fold (0.78 log units) above, and the stated range ends above it.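

Methyl in place of hydrogen on a saturated chain carbon, five bonds along the chain from an aromatic carbon, gives an at least 4.0-fold lower number from compound 2 to compound 3 (0.60 log units; beyond the scatter) in this assay, so the read-out responds to this far part of the chain, which no earlier step had touched. Going by these compounds alone, until now the only known change lay at the cyclopropyl end, and there the number rose; this small addition at the other end moves it the opposite way, and with the cyclopropyl kept in place compound 3 gives a real number, 24.8 ug/mL. The true size of the step stays unknown because compound 2 holds a limit and not a number: the limit of > 100 ug/mL in this assay, at which 1 of the 3 values shown sits.

Going by these compounds, whether a longer chain at this place would lower the number further, or an amine or a carboxylic acid in place of the added methyl would keep the gain, remains open. On these data alone, with one step here, it is also open whether this change would act the same way with propyl in place of the cyclopropyl-bearing group, as in compound 1.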